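The source may report more compounds than this note shows. Statements on the series, on what has been measured and on what is new or still open speak of the compounds shown alone.

Measured compounds in a functional assay on the whole organism (stomach) with Rattus norvegicus as the target; on this read-out higher numbers stand for an effect only at larger amounts of compound and lower numbers for an effect already at smaller amounts:
compound 1, `CC/N=C(/NC#N)NCCCCn1nc(-c2ccccc2)ccc1=O`, 92 mg/kg
compound 2, `C/N=C(\S)NCCCCn1nc(-c2ccccc2)ccc1=O`, 28.9 mg/kg
compound 3, `C/N=C(/NC#N)N(C)CCCCn1nc(-c2ccccc2)ccc1=O`, > 100 mg/kg

The entry for compound 3 is a limit of this assay and not a number, (the limit of > 100 mg/kg in this assay, at which 1 of the 3 values shown sits). Compound 1 gives a measured number, and the step of an at least 1.0-fold higher number from compound 1 to compound 3 (0.03 log units; that floor lies within the scatter) lies within the scatter, so compound 1 and compound 3 cannot be placed in order. Compound 2 sits lowest of the three, since the step of an at least 3.4-fold higher number from compound 2 to compound 3 (0.53 log units; beyond the scatter) is beyond the scatter, as is a 3.2-fold lower number from compound 1 to compound 2 (0.50 log units; beyond the scatter).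

Compound 4, `C/N=C(/NC#N)NCCCCCn1nc(-c2ccccc2)ccc1=O`, is not yet measured. Its change from compound 3 is a group of 8 heavy atoms (4 carbon, 4 nitrogen; no ring) in place of a group of 8 heavy atoms (4 carbon, 4 nitrogen; no ring), on a saturated chain carbon, four bonds along the chain from an aromatic nitrogen. The two groups share the same atoms joined differently, so that compound 4 carries the unsubstituted cyanoguanidine of compound 1 on a longer chain. Going by the values given here, the only measured step that touches this kind of change is an at least 1.0-fold higher number from compound 1 to compound 3 (0.03 log units; that floor lies within the scatter), which is within the scatter. No step beyond the scatter is therefore expected in this assay, and the expected step of an at least 1.0-fold lower number from compound 3 to compound 4 (0.02 log units; that floor lies within the scatter) is small. Compound 4 is estimated at 95 mg/kg, in a range from 40 mg/kg to 220 mg/kg. A fair chance remains that this assay again returns only a limit for compound 4.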

Compound 4, dose for half-maximal effect: 100 mg/kg
Beside the measured number, compound 4's estimate is 1.1-fold (0.02 log units) below it, and the stated range covers the measured number.
By their numbers in this assay, from the lowest: compound 2; then compounds 1 and 4 (each within the scatter of the next).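

In this assay, the shift to the longer chain with the rearranged cyanoguanidine gives a 1.1-fold higher number from compound 1 to compound 4 (0.04 log units; within the scatter), which lies within the scatter, so this change at the saturated chain carbon, four bonds along the chain from an aromatic nitrogen, leaves the read-out without a separable difference. The group with sulfur now stands apart from a second cyanoguanidine compound, with a 3.5-fold higher number from compound 2 to compound 4 (0.54 log units; beyond the scatter), beyond the scatter and of about the same size as the step already seen from compound 1 to compound 2, so among the measured numbers only compound 2 separates from the others. The remaining step is a number no higher from compound 3 to compound 4 (the limit leaves the size open) and its size cannot be read. Compound 3 remains a limit and not a number: the limit of > 100 mg/kg in this assay, at which 1 of the 4 values shown sits.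

The compounds shown do not separate chain length from the change in the cyanoguanidine substituents, since compound 1 and compound 4 differ in both, and a single terminal group carried on a shorter and a longer chain would be needed to tell them apart. From the compounds shown here alone, it also remains open how a urea or a plain amine in place of the cyanoguanidine would read in this assay.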